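Swapping the sulfonyl aryl group on a potent EP3 antagonist

A few compounds are considered here, and "the series" means these few. Any claim that something is new, unique, unknown or untested is made for them only; others in the source may bear on it.

Compound 1 has the structure `Cc1nc(C)c(S(=O)(=O)NC(=O)NC/C=C2\CCCc3cnn(Cc4ccc(Cl)cc4Cl)c32)s1`. In a functional assay on CHO-K1 cells for antagonist activity at prostaglandin E2 receptor EP3 subtype (Homo sapiens), read by TR-FRET and cAMP accumulation, with a stated time of 30 min (on this read-out lower numbers stand for stronger inhibition and higher numbers for weaker inhibition), compound 1 gives 4 nM, the lowest of the two numbers recorded here. Compound 2, `O=C(NC/C(F)=C1\CCCc2cnn(Cc3ccc(C(F)(F)F)cc3)c21)NS(=O)(=O)c1cc(Cl)c(Cl)s1`, gives 52 nM in this assay; the two compounds differ in more than one place, so those values only show that compound 1 is the more potent of the pair, by a margin beyond the usual scatter. Compound 3, `COc1ccccc1S(=O)(=O)NC(=O)NC/C=C1\CCCc2cnn(Cc3ccc(Cl)cc3Cl)c21`, has not yet been measured. It differs from compound 1 in a single place: 2-methoxyphenyl in place of 2,4-dimethyl-1,3-thiazol-5-yl on a sulfonyl sulfur. Among the measured compounds shown here, no directly comparable pair of measured compounds shows what this kind of change does to potency, so the expectation rests on compound 1 alone. A modest loss of potency, somewhat beyond the scatter, is expected, with the step of a 3.0-fold higher number from compound 1 to compound 3 (0.48 log units; beyond the scatter). Compound 3 is therefore estimated at 12 nM, with a likely range from 3 nM to 50 nM.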

Compound 3, half-maximal inhibitory concentration: 114 nM
Compound 3: middle estimate off by 9.5-fold (0.98 log units), on the low side; the measured number lies above the stated range.
By their numbers in this assay, from the lowest: compound 1; then compound 2; then compound 3.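

With the rest of the molecule unchanged, putting 2-methoxyphenyl in place of 2,4-dimethyl-1,3-thiazol-5-yl on the sulfonyl sulfur gives in this assay a 29-fold higher number from compound 1 to compound 3 (1.45 log units; beyond the scatter) and counts as a large step. Among the compounds shown here, this is the first direct sign that potency depends strongly on the aromatic ring held at this place, since compound 1 and compound 2 differ in more than one place and could not show it. One ring swapped for another of similar size, by heavy-atom count, is enough to cost much of the potency of compound 1. Nothing measured here accounts for the loss.

From the compounds shown here alone, it remains open whether the loss follows the methoxy group or the change to a ring of carbon only, which a plain phenyl group could help separate. Also open, going by these compounds, is how a non-aromatic group such as cyclopropyl would fare on the sulfonyl sulfur.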